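Acylhydrazide in place of benzothiazole on the paw edema series

The source may report more compounds than this note shows. Statements on the series, on what has been measured and on what is new or still open speak of the compounds shown alone.

Measured so far:
compound 1 `CCOC(=O)C1=C(C)NC(C)=C(C(=O)OCC)C1c1ccc(OCC(=O)NCc2ccccc2)cc1` — 8.9%
compound 2 `CCOC(=O)C1=C(C)NC(C)=C(C(=O)OCC)C1c1ccc(OCC(=O)Nc2nc3ccccc3s2)cc1` — 64.5%

In a functional assay on the whole organism (strain Wistar) for inhibition, with Rattus norvegicus as the target, read by paw edema, with stated times of 30 min and 2 h, at a dose of 20 mg/kg (a lower number here means less inhibition, a higher number more inhibition at the dose given (going by the name of the read-out)), compound 2 gives 64.5%, the higher of the two numbers; compound 1 gives 8.9% in this assay. Going by the values given here, the one known step, a number 55.6 percentage points higher from compound 1 to compound 2 (beyond the scatter), shows the amide nitrogen substituent matters greatly. Compound 3 `CCOC(=O)C1=C(C)NC(C)=C(C(=O)OCC)C1c1ccc(OCC(=O)NNC(=O)c2sccc2Cl)cc1` differs from compound 2 by ((3-chlorothiophen-2-yl)carbonyl)amino in place of 1,3-benzothiazol-2-yl on an amide-type nitrogen. Among the compounds with values here, no measured step covers an acyl-hydrazide replacement, so the direction rests on the single large step alone. A drop, a number 29.5 percentage points lower from compound 2 to compound 3 (beyond the scatter), is expected. Compound 3 is estimated at 35%, between 10% and 62%.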

Compound 3, a percentage reported as inhibition, in the whole organism at one dose (the size of the read-out at that dose, not a potency): 57.2%
Compound 3: middle estimate off by 22.2 percentage points, on the low side; the range from low to high includes it.
By their numbers in this assay, from the lowest: compound 1; then compounds 3 and 2 (each within the scatter of the next).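

In this assay, ((3-chlorothiophen-2-yl)carbonyl)amino on the amide-type nitrogen reads level with 1,3-benzothiazol-2-yl, a number 7.3 percentage points lower from compound 2 to compound 3 (within the scatter), so in this pair the six-membered aromatic ring is not required for this level of inhibition. Against benzyl the same group gives a number 48.3 percentage points higher from compound 1 to compound 3 (beyond the scatter), so two quite different groups at this position both stand clear of benzyl. No evidence at hand explains why these two groups read alike.

Still open, on these data alone, is whether the chlorine contributes, since an unsubstituted thiophene-2-carbonyl would test this. A simple acetyl in place of the whole acyl group would show whether any aromatic ring is needed here.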